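The compounds below may be only part of what the source reports. "The series", "measured", "known", "first", "only" and "open" are said of these compounds alone.

Measured so far:
compound 2 `C=C1CC[C@H]2C(C)(C)CCC[C@]2(C)[C@H]1C/C=C1/CC(O)OC1=O` — 32000 nM
compound 1 `CC1(C)CCC[C@]2(C)[C@@H](/C=C/C3=CCOC3=O)C(C=O)=CC(=O)[C@@H]12` — 48500 nM

Among the compounds with values here, in a functional assay on SK-N-SH cells (Homo sapiens) for inhibition, read by sulforhodamine B assay (a lower number here means that less compound is tolerated, a higher number that more compound is tolerated), compound 2 gives 32000 nM, which places it at the lower end of the two numbers so far; compound 1 gives 48500 nM, and the gap between the two lies within the scatter, so neither can be called more or less tolerated than the other. Within the data shown here, no pair of measured compounds differs in a single place, so there is no measured step to lean on.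

Compound 3 `C=C1CC[C@H]2C(C)(C)CCC[C@]2(C)[C@H]1C/C=C1/CC(OC)OC1=O` is the next compound in the series. It differs from compound 2 by methyl in place of hydrogen on an oxygen on a saturated carbon, on the carbon bearing the hydroxy of compound 2. Nothing measured here shows how such a change moves the reading; the change is small and adds no donor or acceptor, so the step from compound 2 to compound 3 in this assay is expected to be a 1.1-fold lower number from compound 2 to compound 3 (0.03 log units; within the scatter), not beyond the scatter in either direction. Compound 3 is therefore estimated at 30000 nM, with a range from 10000 nM to 90000 nM.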

Compound 3, concentration lethal to 50% of the cells: 19100 nM
Estimate against measurement, compound 3: 1.6-fold (0.20 log units) above, within the range that was stated.
By their numbers in this assay, from the lowest: compounds 3, 2 and 1 (each within the scatter of the next, the first and the last beyond it).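

Hydroxy to methoxy on this saturated carbon gives a 1.7-fold lower number from compound 2 to compound 3 (0.22 log units; within the scatter) in this assay and is the first step in the series that can be read at a single place. On this pair, the hydrogen on this oxygen can give way to methyl without a reading that can be told apart from that of compound 2, so one added carbon here does not separate the two compounds. Nothing at hand speaks to the reason for this step.

Going by these compounds, whether a longer chain on this oxygen, such as ethoxy or benzyloxy, or an amine or a carboxylic acid in place of the hydroxy, would move the reading beyond the scatter stays open. The step also rests on one pair in one assay, so it cannot be carried over to other places on the shared core.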